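The source may report more compounds than this note shows. Statements on the series, on what has been measured and on what is new or still open speak of the compounds shown alone.

In a functional assay on HCT-8 cells (Homo sapiens) for cytotoxicity (a higher number here means that more compound is needed for the effect, a lower number that less compound is needed), three compounds sharing one core have been measured so far. Compound 1 `COC1=C(C)C(=O)/C(=C(O)/C=C/c2ccc(F)cc2)C(=O)C1(C)C`, carrying 4-fluorophenyl, gives 3.6 ug/mL, and compound 2 `C=Cc1ccccc1/C=C/C(O)=C1/C(=O)C(C)=C(OC)C(C)(C)C1=O`, carrying 2-vinylphenyl, gives 2.1 ug/mL. These two lie within the scatter of each other, with a 1.7-fold lower number from compound 1 to compound 2 (0.23 log units; within the scatter). Compound 3 `COC1=C(C)C(=O)/C(=C(O)/C=C/c2ccco2)C(=O)C1(C)C`, carrying furan-2-yl, gives 17.5 ug/mL, the highest number of the three. The steps to it are a 4.9-fold higher number from compound 1 to compound 3 (0.69 log units; beyond the scatter) and an 8.3-fold higher number from compound 2 to compound 3 (0.92 log units; beyond the scatter), both modest.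

Compound 4 `COC1=C(C)C(=O)/C(=C(O)/C=C/c2cccs2)C(=O)C1(C)C` has not yet been measured. It differs from compound 3 in one place: thiophen-2-yl in place of furan-2-yl on a double-bonded chain carbon bound to a double-bonded chain carbon. That is, thiophen-2-yl stands in place of furan-2-yl on a double-bonded chain carbon bound to a double-bonded chain carbon. Among the compounds with values here, no measured step makes this exact swap. The two modest steps to compound 3 bear on it only indirectly, showing that the group at this place can move the number. Both groups here are five-membered aromatic rings, so a step no larger than those is expected. Compound 3 at 17.5 ug/mL sits at the top of the three, so the expectation leans towards a lower number. The expected step is a 1.9-fold lower number from compound 3 to compound 4 (0.29 log units; within the scatter). For compound 4 the estimate is 9 ug/mL, with an expected range of 3.5 ug/mL to 22 ug/mL.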

Compound 4, concentration for half-maximal effect: 8.6 ug/mL
The estimate for compound 4 lay 1.0-fold (0.02 log units) above the measured number, and the stated range covers the measured number.
By their numbers in this assay, from the lowest: compounds 2 and 1 (each within the scatter of the next); then compound 4; then compound 3.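

In this assay the change from furan-2-yl to thiophen-2-yl keeps the ring size and the heavy-atom count and exchanges only oxygen for sulfur, yet it gives a 2.0-fold lower number from compound 3 to compound 4 (0.31 log units; beyond the scatter) and so shows that this place on the double-bonded chain responds even to a single hetero-atom exchange, though only modestly. The thiophen-2-yl compound still needs more compound than either phenyl-bearing compound, with a 4.1-fold higher number from compound 2 to compound 4 (0.61 log units; beyond the scatter) and a 2.4-fold higher number from compound 1 to compound 4 (0.38 log units; beyond the scatter) as its steps, so both five-membered rings now give higher numbers than both substituted phenyl rings, and none of the four compounds goes against this. No measurement here offers an explanation for these differences.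

The compounds shown leave open whether pyrrol-2-yl, a five-membered aromatic ring with nitrogen as its hetero atom, would fall with the furan-2-yl and thiophen-2-yl compounds, and where an unsubstituted phenyl would stand. They also leave open how a group without an aromatic ring, such as an amine, a carboxylic acid or a longer chain, would behave at this place.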